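This account rests on a few compounds, and the source may have more. Where it says the series, first, only, none or still open, it means among the compounds named here.

Measured in a functional assay on K562 cells (Homo sapiens), read by MTT assay, with a stated time of 72 h; on this read-out lower numbers stand for stronger inhibition and higher numbers for weaker inhibition:
Compound 1 `Nc1nc(N)c2c(-c3cc4ccccc4o3)cn([C@@H]3O[C@H](CO)[C@@H](O)[C@H]3O)c2n1`: > 20000 nM (a limit)
Compound 2 `Cc1nc(N)c2c(-c3ccccc3)cn([C@@H]3O[C@H](CO)[C@@H](O)[C@H]3O)c2n1`: > 20000 nM (a limit)

Compound 2 has no exact number in this assay. Its result, compound 2 at > 20000 nM, is a limit of the assay. Compound 1 also gives only a limit, with compound 1 at > 20000 nM. The data so far therefore come down to the limit of > 20000 nM in this assay, at which 2 of the 2 values shown sit.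

Compound 3 `Cc1nc(N)c2c(-c3cc4ccccc4o3)cn([C@@H]3O[C@H](CO)[C@@H](O)[C@H]3O)c2n1` has not yet been measured. It differs from compound 2 by 1-benzofuran-2-yl in place of phenyl on an aromatic carbon. For the measured compounds named here, no measured step shows what this exchange does in this assay. The nearest guide is compound 1, which carries 1-benzofuran-2-yl and yet reads > 20000 nM, again a limit. On that basis, no change beyond the scatter is expected, and a further limit is the likeliest report. The expected step is a number no higher from compound 2 to compound 3 (the limit leaves the size open). For compound 3 the estimate is 20000 nM, with an expected range from 6000 nM to 30000 nM.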

Compound 3, half-maximal inhibitory concentration: 4990 nM
The estimate for compound 3 lay 4.0-fold (0.60 log units) above the measured number, outside the stated range (below it).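

In this assay, for the compounds shown here, 1-benzofuran-2-yl in place of phenyl on an aromatic carbon of the five-membered aromatic ring gives an at least 4.0-fold lower number from compound 2 to compound 3 (0.60 log units; beyond the scatter), the first sign that the group at this position can change the read-out beyond the scatter. That exchange does not act on its own, however, since methyl in place of amino on an aromatic carbon gives an at least 4.0-fold lower number from compound 1 to compound 3 (0.60 log units; beyond the scatter), even though both compounds carry 1-benzofuran-2-yl. Among these three compounds, a number rather than a limit appears only where 1-benzofuran-2-yl and methyl stand together, and the true size of both steps stays unknown because each starts from a limit: the limit of > 20000 nM in this assay, at which 2 of the 3 values shown sit.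

The compounds shown leave open whether the oxygen of 1-benzofuran-2-yl or its second ring matters more, which a comparison with 2-naphthyl or 1-benzothiophen-2-yl in place of 1-benzofuran-2-yl could begin to separate. They also leave open whether ethyl, a longer chain or a methoxy group in place of methyl would keep, strengthen or lose the inhibition seen with compound 3.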